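The compounds below may be only part of what the source reports. "The series", "measured", "known", "first", "only" and "open" are said of these compounds alone.

Three urea compounds sharing one core have been tested in a functional assay on the whole organism (6C3HED cells, Mus musculus) for inhibition, at a dose of 150 mg/kg by the oral route; on this read-out lower numbers stand for less inhibition and higher numbers for more inhibition at the one dose given (going by the name of the read-out). Compound 1 `CSc1ccc(S(=O)(=O)NC(=O)Nc2ccc(Cl)cc2)s1` gives 29%. Compound 2 `CCc1ccsc1S(=O)(=O)NC(=O)Nc1ccc(Cl)cc1` gives 21%. Compound 3 `COc1csc(S(=O)(=O)NC(=O)Nc2ccc(Cl)cc2)c1` gives 36%. Compound 3 and compound 1 cannot be told apart on this read-out, since a number 7 percentage points higher from compound 1 to compound 3 (within the scatter). Compound 2, however, sits below compound 3, because a number 15 percentage points higher from compound 2 to compound 3 (beyond the scatter). All three differ only in the ring attached to the sulfonyl sulfur.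

Compound 4 `Cc1cc(S(=O)(=O)NC(=O)Nc2ccc(Cl)cc2)sc1C` is not yet measured. It differs from compound 3 in one place: 4,5-dimethylthiophen-2-yl in place of 4-methoxythiophen-2-yl on a sulfonyl sulfur. Going by the values given here, the steps that bear on this are the two swaps of the same ring, which gave only a small change between compound 1 and compound 3 and a modest one between compound 2 and compound 3. Compound 2, which also carries only an alkyl group on its thiophene, gave the lowest number. Compound 4 is therefore expected to fall somewhat below compound 3, with a number 10 percentage points lower from compound 3 to compound 4 (within the scatter), though a result within the scatter would not be surprising. The estimate for compound 4 in this assay is 26%, between 12% and 40%.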

Compound 4, a percentage reported as inhibition, in the whole organism at one dose (the size of the read-out at that dose, not a potency): 42%
Beside the measured number, compound 4's estimate is 16 percentage points below it, and the stated range ends below it.
By their numbers in this assay, from the lowest: compounds 2, 1, 3 and 4 (each within the scatter of the next, the first and the last beyond it).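

Replacing 4-methoxythiophen-2-yl with 4,5-dimethylthiophen-2-yl on the sulfonyl sulfur gives a number 6 percentage points higher from compound 3 to compound 4 (within the scatter) in this assay and so shows that a ring without the methoxy oxygen can read the same as compound 3 on this measure. Carrying only alkyl groups on the thiophene therefore does not by itself mean a low number, as the comparison with the ethyl-bearing ring shows a number 21 percentage points higher from compound 2 to compound 4 (beyond the scatter) and thus that the particular alkyl substitution matters here. The 4,5-dimethylthiophen-2-yl ring also stands clear of the 5-(methylsulfanyl)thiophen-2-yl ring, with a number 13 percentage points higher from compound 1 to compound 4 (beyond the scatter) on this read-out.

From the compounds shown here alone, how a thiophene bearing an amine, a carboxylic acid or a longer chain would behave at this position remains open. The data shown offer no measured explanation for any of these steps.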